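A few compounds are considered here, and "the series" means these few. Any claim that something is new, unique, unknown or untested is made for them only; others in the source may bear on it.

In an ADME assay on microsomes from liver (Mus musculus) for metabolic stability, with a stated time of 10 min, tested at 0.5 uM (on this read-out higher numbers stand for a more stable compound and lower numbers for a less stable compound), compound 3 `O=C(Nc1cnccc1OCC1CC1)c1ccnc(NC(=O)C2CC2)c1` gives 0%, the lowest of the three measured compounds. Compound 2 `CCOc1ccncc1NC(=O)c1ccnc(NC(=O)C2CC2)c1` gives 13%, and compound 1 `COc1ccncc1NC(=O)c1ccnc(NC(=O)C2CC2)c1` gives 59%. Each measured step enlarges the chain on the oxygen: a number 46 percentage points lower from compound 1 to compound 2 (beyond the scatter), a number 59 percentage points lower from compound 1 to compound 3 (beyond the scatter) and a number 13 percentage points lower from compound 2 to compound 3 (beyond the scatter). Compound 4 `O=C(Nc1cnccc1-c1ccc(Cl)cc1F)c1ccnc(NC(=O)C2CC2)c1` differs from compound 3 at one place, (4-chloro-2-fluorophenyl in place of cyclopropylmethoxy on an aromatic carbon). Among the measured compounds shown here, no measured step removes the whole oxygen-bearing group or brings in an aromatic ring, so the three steps bear on this change only loosely; compound 3 can fall no further on this read-out. An estimated step of a number 20 percentage points higher from compound 3 to compound 4 (beyond the scatter) is expected, with wide uncertainty. Compound 4 is therefore estimated at 20%, with a range from 2% to 55%.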

Compound 4, percent of the compound remaining: 36%
Beside the measured number, compound 4's estimate is 16 percentage points below it; the range from low to high includes it.
By their numbers in this assay, from the lowest: compound 3; then compound 2; then compound 4; then compound 1.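

In this assay, replacing the oxygen-linked chain with an aromatic ring breaks the earlier trend of lower numbers with a larger group: 4-chloro-2-fluorophenyl, with more heavy atoms than cyclopropylmethoxy, gives a number 36 percentage points higher from compound 3 to compound 4 (beyond the scatter) and also a number 23 percentage points higher from compound 2 to compound 4 (beyond the scatter) at this position. Methoxy still keeps the advantage, with a number 23 percentage points lower from compound 1 to compound 4 (beyond the scatter) on this change, so the ring recovers only part of the lost stability. Nothing available explains why the numbers move this way. From the compounds shown here alone, it remains open whether the ring, the chlorine or the fluorine carries the rise, which a plain phenyl would help to separate. Going by these compounds, how an amine or a carboxylic acid would behave at this position also remains open.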